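Swapping tert-butyl for cyclobutylmethyl on the ring amine

The source may hold more compounds than are shown below. What is called first, only, known or untested is meant among the compounds shown, and "the series" means these compounds.

Three compounds share one core and differ only in the group on a nitrogen on an aromatic ring: compound 1 `Cc1nc(N)nc(N[C@@H]2C[C@H](CO)[C@@H](O)[C@H]2O)c1-c1nc2ccccc2s1` carries hydrogen there, compound 2 `CCCNc1nc(C)c(-c2nc3ccccc3s2)c(N[C@@H]2C[C@H](CO)[C@@H](O)[C@H]2O)n1` carries propyl, and compound 3 `Cc1nc(NC(C)(C)C)nc(N[C@@H]2C[C@H](CO)[C@@H](O)[C@H]2O)c1-c1nc2ccccc2s1` carries tert-butyl. In an ADME assay on cells (Homo sapiens) for cytotoxicity, read by polymerase chain reaction, with a stated time of 3 days (a higher number here means that more compound is tolerated, a lower number that less compound is tolerated), compound 1 gives 4000 nM and compound 3 gives 12000 nM. For compound 2 the this assay reports only a limit, > 25000 nM. Of the two measured numbers compound 3 stands highest, with a 3.0-fold higher number from compound 1 to compound 3 (0.48 log units; beyond the scatter). Compound 4 `Cc1nc(NCC2CCC2)nc(N[C@@H]2C[C@H](CO)[C@@H](O)[C@H]2O)c1-c1nc2ccccc2s1` has not yet been measured; it differs from compound 3 by cyclobutylmethyl in place of tert-butyl on a nitrogen on an aromatic ring. For the measured compounds named here, the steps that bear on this change are an at least 6.2-fold higher number from compound 1 to compound 2 (0.79 log units; beyond the scatter) and an at least 2.0-fold lower number from compound 2 to compound 3 (0.31 log units; beyond the scatter), since both compare a branched or straight alkyl group at the same nitrogen. Since an at least 2.0-fold lower number from compound 2 to compound 3 (0.31 log units; beyond the scatter), a chain-like group in place of tert-butyl is expected to raise the number again, so for compound 4 the expected step is a 1.7-fold higher number from compound 3 to compound 4 (0.22 log units; within the scatter). The estimate for compound 4 is 20000 nM, with a range from 8000 nM to 50000 nM. The result for compound 4 may itself end up at the limit of > 25000 nM in this assay, at which 1 of the 3 values shown sits.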

Compound 4, half-maximal cytotoxic concentration: > 25000 nM
Compound 4 was reported as a limit; the forecaster's own chance of this, stated with the estimate: 45%; at least 1.2-fold (0.09 log units) between middle value and limit.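

In this assay, cyclobutylmethyl at this nitrogen gives an at least 2.0-fold higher number from compound 3 to compound 4 (0.31 log units; beyond the scatter), so a group attached through a chain carbon and carrying a four-membered ring does not hold the number down as tert-butyl does in compound 3. Measured against the bare amine, the change gives an at least 6.2-fold higher number from compound 1 to compound 4 (0.79 log units; beyond the scatter), which makes cyclobutylmethyl the second group, after propyl, with a step of this reach from hydrogen. Compound 2 and compound 4 are both reported only as limits, so the step between them cannot be read: the limit of > 25000 nM in this assay, at which 2 of the 4 values shown sit.

As far as these compounds go, how propyl and cyclobutylmethyl rank against each other therefore stays open. So does whether a longer chain such as butyl, or a chain ending in a hydroxyl or an amine, would also reach this limit.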